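Changing the group on sulfur in compound 2

The source may hold more compounds than are shown below. What is called first, only, known or untested is meant among the compounds shown, and "the series" means these compounds.

In a functional assay on the whole organism with Canis familiaris (Canis lupus familiaris) as the target (a higher number here means that more compound is needed for the effect, a lower number that less compound is needed), two compounds have been measured so far. Compound 1 (`OC(CSc1[nH]cnc2ncnc1-2)CN1CCN(C(c2cccc(C(F)(F)F)c2)c2cccc(C(F)(F)F)c2)CC1`) gives 1.1 mg/kg and compound 2 (`Nc1nc(SCC(O)CN2CCN(C(c3ccc(F)cc3)c3ccc(F)cc3)CC2)c2[nH]cnc2n1`) gives 0.85 mg/kg in this read-out of the dose for half-maximal effect. Compound 2 therefore stands within the scatter of compound 1, although the two structures differ in more than one place. Compound 3 (`Cn1cnc2c(SCC(O)CN3CCN(C(c4ccc(F)cc4)c4ccc(F)cc4)CC3)ncnc21`) differs from compound 2 only on a sulfur, where a group of 10 heavy atoms (6 carbon, 4 nitrogen; one five-membered aromatic ring with 2 hetero atoms, one six-membered aromatic ring with 2 hetero atoms) in place of a group of 10 heavy atoms (5 carbon, 5 nitrogen; one five-membered aromatic ring with 2 hetero atoms, one six-membered aromatic ring with 2 hetero atoms), on a sulfur describes the exchange. The hydrogen-bond donors of the leaving group are absent from the entering group. Going by the values given here, no measured pair shows this kind of change, so the size of the step remains a judgement. A move beyond the scatter toward a higher number is expected. The expected step is a 3.5-fold higher number from compound 2 to compound 3 (0.55 log units; beyond the scatter) in size. Compound 3 is estimated at 3 mg/kg with a range from 0.8 mg/kg to 12 mg/kg expected.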

Compound 3, dose for half-maximal effect: 1.9 mg/kg
For compound 3 the middle estimate is 1.6-fold (0.20 log units) above the measured one, and the stated range covers the measured number.
By their numbers in this assay, from the lowest: compounds 2, 1 and 3 (each within the scatter of the next, the first and the last beyond it).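

In this assay, going by these compounds alone, the exchange on a sulfur gives the first measured step at this position, a 2.2-fold higher number from compound 2 to compound 3 (0.35 log units; beyond the scatter), and it is modest but beyond the scatter. The position therefore responds to the group it carries, even though the leaving and entering groups share the same count of 10 heavy atoms, the same two aromatic rings and 4 hydrogen-bond acceptors, and differ in carbon and nitrogen counts and in having 0 rather than 2 hydrogen-bond donors. Nothing measured explains why the number moves.

With this single step, the loss of the donors cannot be separated from the other differences between the two groups. From the compounds shown here alone, how a group bearing a carboxylic acid, or a longer chain, on the sulfur would shift the dose remains open.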